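One extra methyl on a compound at the assay limit

The source may report more compounds than this note shows. Statements on the series, on what has been measured and on what is new or still open speak of the compounds shown alone.

In a physicochemical assay for lipophilicity, using the shake flask method, in phosphate buffer, measured as octanol-water partition, at pH 7.4 (on this read-out lower numbers stand for lower lipophilicity and higher numbers for higher lipophilicity), compound 1 `C[C@@H]1CN(c2ncc(OCc3ccc(S(C)(=O)=O)cc3)cn2)CCN1C(=O)OC(C)(C)C` gives > 3.7, which is a limit and not a number. In this assay compound 2 `C[C@H]1CN(c2ncc(OCc3ccc(S(C)(=O)=O)cc3)cn2)CCN1C(=O)OC(C)(C)C` gives > 3.6, also a limit. So the starting point of this comparison has no exact value.

Compound 3 `C[C@@H]1CN(c2ncc(OCc3ccc(S(C)(=O)=O)cc3)cn2)[C@@H](C)CN1C(=O)OC(C)(C)C` is compound 1 with a single change: methyl in place of hydrogen on a saturated ring carbon. That carbon belongs to a six-membered non-aromatic ring with 2 nitrogen. The new methyl sits next to the ring nitrogen and two ring bonds from the ring atom that bears a tert-butoxycarbonyl group.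

For the measured compounds named here, the only measured comparison is a step that the two limits leave unreadable from compound 1 to compound 2. It concerns (the fact that compounds 1 and 2 differ only in the configuration as drawn), so it offers no size to carry over to an added methyl. Going by the values given here, no measured pair here adds such a group, and the forecast therefore remains a cautious judgement.

A modest upward movement is expected, with an estimated size of a step that the limit leaves unreadable from compound 1 to compound 3. Compound 3 is expected to give about 4.1, within an estimated range from 3.7 to 4.6.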

Compound 3, distribution coefficient: > 3.7
Compound 3 gave a limit, no number; the forecaster's own chance of this, stated with the estimate: 75%; the middle value lies beyond the limit too.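

In this assay compound 3 gives > 3.7, which is a limit and not a number. Compound 1 gives > 3.7, also a limit, so the step between compound 1 and compound 3 cannot be read. The compounds shown leave open how far, and in which direction, the added methyl shifts the distribution coefficient.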